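This account rests on a few compounds, and the source may have more. Where it says the series, first, only, none or still open, it means among the compounds named here.

Measured compounds:
Compound 1 `CC(C)(C)OC(=O)N1CCC(Oc2cc(Oc3ccc(/C=C4\SC(=O)NC4=O)cc3)ncn2)CC1`: 130 nM in a functional assay on CHO-K1 cells for agonist activity at Glucose-dependent insulinotropic receptor (Homo sapiens), read by cAMP accumulation and immunoassay, with a stated time of 1 h; on this read-out higher numbers stand for an effect only at larger amounts of compound and lower numbers for an effect already at smaller amounts
Compound 2 `CC(C)COC(=O)N1CCC(Oc2cc(Oc3ccc(/C=C4\SC(=O)NC4=O)cc3)ncn2)CC1`: 745 nM in this assay
Compound 3 `CC(C)(C)OC(=O)N1CCC(Oc2cc(Oc3cccc(/C=C4\SC(=O)NC4=O)c3)ncn2)CC1`: 125 nM in this assay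

Compound 1 and compound 3 share the same atoms joined differently; the difference between the two cores is not broken down here. Their values in this assay lie within the usual scatter of each other. Compound 1 to compound 2 carries isobutyl in place of tert-butyl on an oxygen next to a carbonyl group, which gave a 5.7-fold higher number from compound 1 to compound 2 (0.76 log units; beyond the scatter).

Compound 4 `CC(C)COC(=O)N1CCC(Oc2cc(Oc3cccc(/C=C4\SC(=O)NC4=O)c3)ncn2)CC1` is not yet measured. It differs from compound 3 by isobutyl in place of tert-butyl on an oxygen next to a carbonyl group, the same change at the same place as from compound 1 to compound 2. A step of about the same size is expected, a 5.6-fold higher number from compound 3 to compound 4 (0.75 log units; beyond the scatter), because the same change gave a 5.7-fold higher number from compound 1 to compound 2 (0.76 log units; beyond the scatter). Compound 4 is therefore estimated at 700 nM in this assay, with a range from 300 nM to 1800 nM.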

Compound 4, half-maximal effective concentration: 720 nM
Compound 4: the middle estimate sits 1.0-fold (0.01 log units) below what was measured; measured number inside the range.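

In this assay, isobutyl in place of tert-butyl on an oxygen next to a carbonyl group gave a 5.8-fold higher number from compound 3 to compound 4 (0.76 log units; beyond the scatter), so the change carried from the core of compound 1 to the core of compound 3 with its size unchanged: the same change on two cores in this assay, a 5.7-fold higher number (0.76 log units; beyond the scatter) from compound 1 to compound 2 and a 5.8-fold higher number (0.76 log units; beyond the scatter) from compound 3 to compound 4, 1.0-fold (0.00 log units) apart, within the scatter of two such steps. This covers only these two closely related cores and this single pair of groups. It does not show that the step would keep its size on other cores, and it does not explain why the isobutyl compounds give the higher numbers.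

Still open, from the compounds shown here alone, is how other groups on that oxygen would behave, such as a longer chain like n-butyl or a cyclopropylmethyl group. Also open, going by these compounds, is whether an amine in place of that oxygen would follow the same trend.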